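A Single Measured Compound and a Nitrile Swap

The source may hold more compounds than are shown below. What is called first, only, known or untested is meant among the compounds shown, and "the series" means these compounds.

Three compounds sharing one core have gone into a functional assay on MCF7 cells (Homo sapiens) for cytotoxicity, read by MTT assay, with a stated time of 72 h (on this read-out lower numbers stand for stronger inhibition and higher numbers for weaker inhibition), so far, and only one of them gave a number. In this assay compound 1 `CNC(=O)c1cc(Oc2ccc(C(=O)/C=C/c3ccco3)cc2)ccn1` stands as "not determined" (no result reported) and compound 2 `CNC(=O)c1cc(Oc2ccc(C(=O)/C=C/c3ccc([N+](=O)[O-])cc3)cc2)ccn1` stands as "not determined" (no result reported) in the record. Among the compounds with values here, compound 3 `CNC(=O)c1cc(Oc2ccc(C(=O)/C=C/c3ccc(F)cc3Cl)cc2)ccn1` gives 21100 nM and is the only number available, so it cannot yet be ranked against any other compound.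

Compound 4 `CNC(=O)c1cc(Oc2ccc(C(=O)/C=C/c3ccc(C#N)cc3)cc2)ccn1` keeps the shared core and changes one group: 4-cyanophenyl in place of 2-chloro-4-fluorophenyl on a double-bonded chain carbon bound to a double-bonded chain carbon. Within the data shown here, no pair of measured compounds shows how far such a swap can move a result in this assay, and the data favour no direction. Among the measured compounds shown here, the only anchor is compound 3 at 21100 nM and so the expectation stays close to it, with a wide margin. The expected change a 1.1-fold lower number from compound 3 to compound 4 (0.02 log units; within the scatter) is no larger than the usual scatter. Compound 4 is estimated at 20000 nM (expected range 7000 nM to 55000 nM).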

Compound 4, half-maximal inhibitory concentration: 9520 nM
The estimate for compound 4 lay 2.1-fold (0.32 log units) above the measured number, and the stated range covers the measured number.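

Within the data shown here, this is the first step between two measured compounds in this assay, and it shows that the group on a double-bonded chain carbon bound to a double-bonded chain carbon can change the result: 4-cyanophenyl in place of 2-chloro-4-fluorophenyl gives a 2.2-fold lower number from compound 3 to compound 4 (0.35 log units; beyond the scatter) and so a modest gain that exceeds the usual scatter. The change removes both halogens and brings in a nitrile with its hydrogen-bond acceptor, so this single step cannot separate the part played by each of these differences. Nothing measured here accounts for the shift, and its cause remains unknown.

Compound 1 and compound 2 carry no number and add no comparison. Still open, from the compounds shown here alone, is how far the result would move, and in which direction, with an amine or a carboxylic acid in place of the nitrile, or with chlorine or fluorine alone on the ring.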